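Removing a Methyl From a Compound Without Measurable Activity

The source may hold more compounds than are shown below. What is called first, only, known or untested is meant among the compounds shown, and "the series" means these compounds.

Measured compounds:
compound 1 `Clc1ccc(Cc2nn3cc(-c4ccccc4)nc3s2)cc1` gives > 250000 nM
compound 2 `Cc1ccc(-c2nc3sc(Cc4ccc(Cl)cc4)nn3c2Br)cc1` gives > 250000 nM

Both values come from a functional assay on L1210 cells (Mus musculus) for cytotoxicity, with a stated time of 48 h; on this read-out lower numbers stand for stronger inhibition and higher numbers for weaker inhibition. For compound 1 the value > 250000 nM is a limit of the assay, not a number. For compound 2 the value > 250000 nM is likewise a limit of the assay. Going by the values given here, compound 2 therefore stands nowhere on a scale of numbers: it sits at the limit of > 250000 nM in this assay, at which 2 of the 2 values shown sit, and the only other value known shares that limit. Among the compounds with values here, no pair of measured compounds differs in a single place, so no measured step exists.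

Compound 3 `Clc1ccc(Cc2nn3c(Br)c(-c4ccccc4)nc3s2)cc1` is the compound still to be measured. It differs from compound 2 by hydrogen in place of methyl on an aromatic carbon, para to a large group, so that a 4-methylphenyl becomes a phenyl. Since compound 2 gives only a limit in this assay, the step that the limit leaves unreadable from compound 2 to compound 3 is expected to be none beyond the scatter, with the result most likely again a limit. Compound 3 is accordingly estimated at 300000 nM, within 100000 nM to 1000000 nM.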

Compound 3, half-maximal inhibitory concentration: > 250000 nM
Compound 3: a limit, no number; the forecaster's own chance of this, stated with the estimate: 85%; the middle value is on the limit's open side.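

No step can be read among compound 1, compound 2 and compound 3, because each gives a limit of the assay rather than a number: the limit of > 250000 nM in this assay, at which 3 of the 3 values shown sit. The compounds shown leave open whether hydrogen in place of methyl, or bromo in place of hydrogen, has any effect at all, and which change would yield a measurable value.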